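A few compounds are considered here, and "the series" means these few. Any claim that something is new, unique, unknown or untested is made for them only; others in the source may bear on it.

The measured compounds:

compound 1 `CN(Cc1cccc(F)c1)C(=O)CN(C)C(=O)c1ccc(S(C)(=O)=O)c([N+](=O)[O-])c1` — > 27000 nM
compound 2 `CN(Cc1cccc(F)c1)C(=O)CNC(=O)c1ccc(S(C)(=O)=O)c([N+](=O)[O-])c1` — > 27000 nM

In an ADME assay on HepG2 cells (Homo sapiens) for cytotoxicity, read by CellTiter-Glo and ATP content, with a stated time of 72 h (a lower number here means that less compound is needed, a higher number that more compound is needed for the effect), compound 1 gives > 27000 nM, which is a limit of the assay and not a number. Compound 2, in this assay, likewise gives > 27000 nM, again a limit. Within the data shown here, the single measured step, a step that the two limits leave unreadable from compound 1 to compound 2, therefore cannot be read, and compound 1 is placed only by the limit of > 27000 nM in this assay, at which 2 of the 2 values shown sit.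

Compound 3 `CN(CC(=O)N1CCc2ccccc2C1)C(=O)c1ccc(S(C)(=O)=O)c([N+](=O)[O-])c1` differs from compound 1 in one place: 1,2,3,4-tetrahydroisoquinolin-2-yl in place of (3-fluorobenzyl)(methyl)amino on a carbonyl carbon. Among the measured compounds shown here, no measured step touches this change, and the one step that exists is itself unreadable, so no direction or size can be drawn from the data. Compound 3 is expected to sit at the same limit, a step that the limit leaves unreadable from compound 1 to compound 3 that is not expected to be readable. The estimate for compound 3 in this assay is 40000 nM, with a range from 15000 nM to 150000 nM.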

Compound 3, half-maximal effective concentration: > 27000 nM
Compound 3: a limit, no number; the forecaster's own chance of this, stated with the estimate: 85%; the middle value does not contradict the limit.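

In this assay compound 3 gives > 27000 nM, a limit and not a number, so the step from compound 1 to compound 3 cannot be read: the limit of > 27000 nM in this assay, at which 3 of the 3 values shown sit.

The compounds shown leave open whether either change among compound 1, compound 2 and compound 3 alters the read-out in this assay at all.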